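Notes on replacing 2-nitrophenyl with 3,4-dimethoxyphenyl

A few compounds are considered here, and "the series" means these few. Any claim that something is new, unique, unknown or untested is made for them only; others in the source may bear on it.

Measured in an ADME assay on HEK293 cells (Homo sapiens) for cytotoxicity, read by MTT assay, with a stated time of 48 h; a lower number here means a stronger inhibitor, a higher number a weaker inhibitor:
compound 1 `Cc1ccc(S(=O)(=O)/N=C(/CCNC2=CC(=O)c3ccccc3C2=O)Nc2ccccc2[N+](=O)[O-])cc1` gives 69600 nM
compound 2 `Cc1ccc(S(=O)(=O)/N=C(/CCNC2=CC(=O)c3ccccc3C2=O)Nc2cccc(C)c2)cc1` gives 56200 nM
compound 3 `Cc1ccc(S(=O)(=O)/N=C(/CCNC2=CC(=O)c3ccccc3C2=O)Nc2cccc(C(F)(F)F)c2)cc1` gives 91500 nM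

Compound 1 holds the second highest of the three numbers. The nearest is compound 2, reached by a 1.2-fold lower number from compound 1 to compound 2 (0.09 log units; within the scatter); the furthest is compound 3, reached by a 1.3-fold higher number from compound 1 to compound 3 (0.12 log units; within the scatter). Between the two substituted phenyl compounds the step is a 1.6-fold higher number from compound 2 to compound 3 (0.21 log units; within the scatter). All three steps lie within the scatter.

Compound 4 `COc1ccc(N/C(CCNC2=CC(=O)c3ccccc3C2=O)=N\S(=O)(=O)c2ccc(C)cc2)cc1OC` differs from compound 1 by 3,4-dimethoxyphenyl in place of 2-nitrophenyl on an amine nitrogen.

The two steps from compound 1 to compound 2 and from compound 1 to compound 3 bear directly on this change: each swaps the 2-nitrophenyl on the amine nitrogen for a differently substituted phenyl, and neither moves the number beyond the scatter. Among the measured compounds shown here, no step in this set exceeds the scatter, so no direction can be read from it. For compound 4 a change of a 1.0-fold lower number from compound 1 to compound 4 (0.01 log units; within the scatter) is therefore expected, which is no step beyond the scatter. Compound 4 is estimated at 68000 nM, with a range from 35000 nM to 130000 nM.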

Compound 4, half-maximal inhibitory concentration: 60600 nM
Compound 4: middle estimate off by 1.1-fold (0.05 log units), on the high side; the range from low to high includes it.
By their numbers in this assay, from the lowest: compounds 2, 4, 1 and 3 (each within the scatter of the next).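

In this assay, the group on the amine nitrogen now spans 2-nitrophenyl, 3-methylphenyl, 3-(trifluoromethyl)phenyl and 3,4-dimethoxyphenyl, and the new group separates from none of the others: a 1.1-fold lower number from compound 1 to compound 4 (0.06 log units; within the scatter), a 1.1-fold higher number from compound 2 to compound 4 (0.03 log units; within the scatter) and a 1.5-fold lower number from compound 3 to compound 4 (0.18 log units; within the scatter). Among the compounds shown here, the flat picture at this place therefore extends to a phenyl carrying methoxy groups, a substitution not covered by the earlier compounds, and still no direction can be read from the series. Nothing measured here offers an explanation for this result.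

Still open, going by these compounds, is whether the numbers stay this close when the phenyl gives way to cyclohexyl or a pyridine ring, or when the phenyl carries a carboxylic acid or an amine. The compounds shown also leave open whether any group at this place produces a step beyond the scatter.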